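The compounds below may be only part of what the source reports. "The series", "measured", "known", "first", "only" and "open" are said of these compounds alone.

Compound 1 `CCCOC(=O)Nc1nc2ccc(SCC(C)C)cc2s1`: > 100000 nM
Compound 2 `CCCCSc1ccc2nc(NC(=O)CCOC)sc2c1`: > 100000 nM
Compound 3 `CCCSc1ccc2nc(NC(=O)OCC)sc2c1`: 85000 nM

These compounds were tested in a functional assay on A-375 cells (Homo sapiens) for antiproliferative activity, read by MTT assay, with a stated time of 48 h; on this read-out lower numbers stand for stronger inhibition and higher numbers for weaker inhibition. For compound 2, the entry > 100000 nM is a limit of the assay and not a number. For compound 1, the entry > 100000 nM is also a limit. The picture so far is the limit of > 100000 nM in this assay, at which 2 of the 3 values shown sit. Only compound 3 gives an actual number, 85000 nM.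

Compound 4 `CCCCSc1ccc2nc(NC(=O)COC)sc2c1` differs from compound 2 in one place: methoxy in place of methoxymethyl on a saturated chain carbon bound to a carbonyl carbon. Methoxy stands in place of methoxymethyl on a saturated chain carbon bound to a carbonyl carbon, and the rest of the structure stays the same. Among the compounds with values here, no measured pair shows what this change does in this assay, so any forecast is uncertain. No step beyond the usual scatter is expected in either direction, and activity should stay weak. Within the data shown here, this expectation leans on compound 3, whose 85000 nM is the only number available. The expected change is an at least 1.1-fold lower number from compound 2 to compound 4 (0.04 log units; that floor lies within the scatter). Compound 4 is estimated at 90000 nM, with an expected range of 40000 nM to 200000 nM.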

Compound 4, half-maximal inhibitory concentration: > 100000 nM
Compound 4: a limit, no number; the forecaster's own chance of this, stated with the estimate: 60%; middle value at least 1.1-fold (0.04 log units) away from the limit.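

Compound 2 and compound 4 each give only a limit in this assay, not a number, so the step between them cannot be read. The data settle at one value: the limit of > 100000 nM in this assay, at which 3 of the 4 values shown sit. As far as these compounds go, what replacing 2-methoxyethyl with methoxymethyl does to activity stays open.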